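Benzyl in place of phenyl on the 8-carboxyoctyl compound

The source may report more compounds than this note shows. Statements on the series, on what has been measured and on what is new or still open speak of the compounds shown alone.

Among the measured compounds shown here, in a functional assay for inhibition, with Homo sapiens as the target (a lower number here means a stronger inhibitor, a higher number a weaker inhibitor), compound 2 `O=C(O)CCCCCCCCn1nc(-c2ccccc2)c(-c2ccccc2)c1-c1ccccc1` gives 400 nM, the lowest of the three numbers so far. Compound 1 `COC(=O)CCCCCCCCn1nc(-c2ccccc2)c(-c2ccccc2)c1-c1ccccc1` gives 4300 nM, and compound 3 `O=C(O)CCCCCCCCCCn1nc(-c2ccccc2)c(-c2ccccc2)c1-c1ccccc1` gives 18600 nM. Two measured steps lead to or from compound 2: an 11-fold lower number from compound 1 to compound 2 (1.03 log units; beyond the scatter), and a 47-fold higher number from compound 2 to compound 3 (1.67 log units; beyond the scatter). Both are large, so single changes can move this series well beyond the scatter. Neither step alters a group on the aromatic carbon that changes next, so they give only a rough sense of scale, not a direct precedent.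

Compound 4 `O=C(O)CCCCCCCCn1nc(-c2ccccc2)c(Cc2ccccc2)c1-c1ccccc1` carries benzyl in place of phenyl on an aromatic carbon. Compound 2 at 400 nM sits lowest so far, so a move to a higher number is the more likely direction, though the data do not establish it. The expected step is modest, a 3.0-fold higher number from compound 2 to compound 4 (0.48 log units; beyond the scatter), and this estimate is uncertain. Compound 4 is estimated at 1200 nM, with an expected range of 300 nM to 6000 nM.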

Compound 4, half-maximal inhibitory concentration: > 68000 nM
Compound 4: only a limit was reported; the forecaster's own chance of this, stated with the estimate: 5%; middle value at least 56-fold (1.75 log units) away from the limit.
By their numbers in this assay, from the lowest: compound 2; then compound 1; then compound 3. At a limit, above all of these: compound 4.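

At the aromatic carbon next to two ring atoms that each bear a phenyl group, replacing phenyl (6 heavy atoms) with benzyl (7 heavy atoms) is not a small edit: an at least 170-fold higher number from compound 2 to compound 4 (2.23 log units; beyond the scatter). In this assay compound 4 gives > 68000 nM, which is a limit and not a number. The earlier steps changed only the chain or its end group, so this is the first sign that the group on this aromatic carbon alone can move the number as far as they did, and the reading rests on a single limit: the limit of > 68000 nM in this assay, at which 1 of the 4 values shown sits.

Still open, on these data alone, is whether a smaller group on this carbon, such as methyl or chlorine, keeps a number near that of compound 2 at 400 nM. Also open, as far as these compounds go, is whether benzyl on either of the other two phenyl-bearing ring atoms gives a step of similar size.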